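The compounds below may be only part of what the source reports. "The series", "measured", "known", "first", "only" and "open" are said of these compounds alone.

Of the compounds shown here, three have been measured so far in an ADME assay on the whole organism (plasma, Rattus norvegicus) for protein binding, using cassette dosing, at a dose of 1 mg/kg (on this read-out higher numbers stand for a larger free fraction and lower numbers for a smaller free fraction), on this series. Compound 1 `CC(C)Oc1ccc(/N=c2\[nH]c(=O)n(C[C@@H](C)C(=O)O)c(=O)n2Cc2ccc(Cl)cc2)cc1Cl` gives 0.002 there and compound 3 `CC(C)Oc1ccc(Nc2nc(=O)n(CCO)c(=O)n2Cc2ccc(Cl)cc2)cc1Cl` gives 0.001 there. Compound 2 `C[C@@H](Cn1c(=O)[nH]/c(=N\c2ccc(Oc3nccs3)cc2)n(Cc2ccc(Cl)cc2)c1=O)C(=O)O` gives 0.006 and so stands highest of the three, beyond the scatter from both others. Within the data shown here, compound 4 `C[C@@H](Cn1c(=O)[nH]/c(=N\c2ccc(Oc3ccccn3)cc2)n(Cc2ccc(Cl)cc2)c1=O)C(=O)O` carries pyridin-2-yl in place of 1,3-thiazol-2-yl on an oxygen on an aromatic ring, its only difference from compound 2 (pyridin-2-yl in place of 1,3-thiazol-2-yl on an oxygen on an aromatic ring). Among the measured compounds shown here, no measured pair shows this change directly, so the expectation is tentative. The expected step in this assay is a 1.5-fold lower number from compound 2 to compound 4 (0.18 log units; within the scatter) and it is a small fall that stays within the scatter. Compound 4 is estimated at 0.004 with an expected range of 0.002 to 0.008 on this read-out.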

Compound 4, unbound fraction: 0.01
Estimate against measurement, compound 4: 2.5-fold (0.40 log units) below, and the stated range ends below it.
By their numbers in this assay, from the lowest: compounds 3 and 1 (each within the scatter of the next); then compounds 2 and 4 (each within the scatter of the next).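

In this assay pyridin-2-yl in place of 1,3-thiazol-2-yl on an oxygen on an aromatic ring gives a 1.7-fold higher number from compound 2 to compound 4 (0.22 log units; within the scatter) and so stays within the scatter. This first one-place pair shows that, at this position, the six-membered and five-membered rings cannot be told apart on this read-out. Nothing measured here bears on the size of this step. The compounds shown leave open whether phenyl or pyrimidin-2-yl on the same oxygen would also stay within the scatter of compound 2, and whether an amine on that aromatic ring in place of the oxygen-linked group would move the read-out beyond it.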